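This account rests on a few compounds, and the source may have more. Where it says the series, first, only, none or still open, it means among the compounds named here.

Measured in a toxicity assay on MT4 cells (Homo sapiens) for cytotoxicity, read by MTT assay; a higher number here means that more compound is tolerated, a lower number that less compound is tolerated:
compound 1 `Cc1cc(-c2ccc(F)cc2)cc(C)c1Oc1cc(N)nc(Nc2ccc(C#N)cc2)n1` gives 23100 nM
compound 2 `Cc1cccc(-c2cc(C)c(Oc3cc(N)nc(Nc4ccc(C#N)cc4)n3)c(C)c2)c1` gives 27600 nM

Compound 2 stands alongside compound 1, as the step of a 1.2-fold higher number from compound 1 to compound 2 (0.08 log units; within the scatter) lies within the scatter. Compound 3 `COc1ccc(-c2cc(C)c(Oc3cc(N)nc(Nc4ccc(C#N)cc4)n3)c(C)c2)cc1` differs from compound 2 in one place: 4-methoxyphenyl in place of 3-methylphenyl on an aromatic carbon. Going by the values given here, the only step that bears on this is the one from compound 1 to compound 2, which also exchanged the group on that aromatic carbon and left the number within the scatter. Compound 3 is therefore expected to show no step beyond the scatter in this assay, the estimated step being a 1.0-fold lower number from compound 2 to compound 3 (0.01 log units; within the scatter). Compound 3 is estimated at 27000 nM, with a range from 13000 nM to 55000 nM.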

Compound 3, half-maximal cytotoxic concentration: 10700 nM
Compound 3: middle estimate off by 2.5-fold (0.40 log units), on the high side; the whole stated range lies above it.
By their numbers in this assay, from the lowest: compound 3; then compounds 1 and 2 (each within the scatter of the next).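

In this assay, going by these compounds alone, the group on this aromatic carbon turns out to matter: the 4-methoxyphenyl gives the first change beyond the scatter, a 2.6-fold lower number from compound 2 to compound 3 (0.41 log units; beyond the scatter), and methoxy in place of fluoro gives a 2.2-fold lower number from compound 1 to compound 3 (0.33 log units; beyond the scatter), both modest. The exchange between the earlier pair had left the number within the scatter, so this carbon is not indifferent to every group it carries. Nothing shown accounts for this shift. As far as these compounds go, it remains open whether a 4-methylphenyl would stand with compound 2 or with compound 3. From the compounds shown here alone, how the number would respond to a 4-hydroxyphenyl or an amine on this ring is also open.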